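Benzyl ester in place of methoxyethyl ester on a dihydropyridine

A few compounds are considered here, and "the series" means these few. Any claim that something is new, unique, unknown or untested is made for them only; others in the source may bear on it.

The three measured compounds are:
compound 1, `COCCOC(=O)C1=C(C)NC(C)=C(C(=O)OC)C1c1cnc(SC)n1Nc1ccccc1`, 9.65 nM;
compound 2, `COC(=O)C1=C(C)NC(C)=C(C(=O)OCc2ccccc2)C1c1cnc(SC)n1Nc1ccccc1`, 2.21 nM;
compound 3, `CCOC(=O)C1=C(C)NC(C)=C(C(=O)OCCOC)C1c1cnc(SC)n1Nc1ccccc1`, 2.91 nM.

All three were tested in an assay on isolated protein (strain albino) for antagonist activity at Voltage-dependent L-type calcium channel subunit alpha-1C (Cavia porcellus); a lower number here means a stronger inhibitor, a higher number a weaker inhibitor. They share one core and differ only in the two ester groups. Compound 1 carries the smallest esters; compound 2 differs from it by phenyl in place of methoxymethyl on a saturated chain carbon bound to an oxygen next to a carbonyl group and gives a 4.4-fold lower number from compound 1 to compound 2 (0.64 log units; beyond the scatter). Compound 3 differs from compound 1 by methyl in place of hydrogen on a saturated chain carbon bound to an oxygen next to a carbonyl group and gives a 3.3-fold lower number from compound 1 to compound 3 (0.52 log units; beyond the scatter). Compound 2 and compound 3 lie within the scatter of each other, so no order between them can be read.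

Compound 4, `CCOC(=O)C1=C(C)NC(C)=C(C(=O)OCc2ccccc2)C1c1cnc(SC)n1Nc1ccccc1`, has not yet been measured. It differs from compound 3 by phenyl in place of methoxymethyl on a saturated chain carbon bound to an oxygen next to a carbonyl group. This is the same change as that from compound 1 to compound 2, made on the core of compound 3 rather than that of compound 1; the two cores differ by methyl in place of hydrogen on a saturated chain carbon bound to an oxygen next to a carbonyl group. The earlier step of this change was a 4.4-fold lower number from compound 1 to compound 2 (0.64 log units; beyond the scatter).

Compound 4 is expected to show a step of about a 3.2-fold lower number from compound 3 to compound 4 (0.51 log units; beyond the scatter), resting on the one earlier occurrence of the change, which gave a 4.4-fold lower number from compound 1 to compound 2 (0.64 log units; beyond the scatter), and on the value of compound 3, 2.91 nM. Going by the values given here, since only one example of the change is available, and both measured esters of compound 2 and compound 3 already lie close together, the expected step is taken as somewhat smaller than the earlier one. Compound 4 is therefore estimated at 0.9 nM, with a likely range from 0.35 nM to 2.5 nM.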

Compound 4, half-maximal inhibitory concentration: 1.86 nM
Estimate against measurement, compound 4: 2.1-fold (0.32 log units) below; measured number inside the range.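

In this assay, the change from 2-methoxyethyl to benzyl gives a 1.6-fold lower number from compound 3 to compound 4 (0.19 log units; within the scatter), and its two occurrences do not match: the same change on two cores in this assay, a 4.4-fold lower number (0.64 log units; beyond the scatter) from compound 1 to compound 2 and a 1.6-fold lower number (0.19 log units; within the scatter) from compound 3 to compound 4, 2.8-fold (0.45 log units) apart, beyond the scatter of two such steps. The methyl in place of hydrogen on a saturated chain carbon bound to an oxygen next to a carbonyl group gives a 1.2-fold lower number from compound 2 to compound 4 (0.07 log units; within the scatter), and this change also fails to carry over at its earlier size: the same change on two cores in this assay, a 3.3-fold lower number (0.52 log units; beyond the scatter) from compound 1 to compound 3 and a 1.2-fold lower number (0.07 log units; within the scatter) from compound 2 to compound 4, 2.8-fold (0.45 log units) apart, beyond the scatter of two such steps. The size of each step on the core of compound 1 therefore did not hold on the second core, and compound 2, compound 3 and compound 4 lie within the scatter of each other and cannot be ordered, but these four compounds do not show why the steps differ or whether the same would be seen on any other core in the series.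

The compounds shown leave open whether other ester groups, such as a longer chain or a chain ending in an amine, would sit with compound 2, compound 3 and compound 4 or with compound 1. They also leave open whether a benzyl ester carrying a fluorine or a methoxy group on its ring would keep the step seen here.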